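Aryl Ketone Variation on a Trimethoxyphenyl-Bearing Fused Core

A few compounds are considered here, and "the series" means these few. Any claim that something is new, unique, unknown or untested is made for them only; others in the source may bear on it.

Of the compounds shown here, two have been tested so far. Compound 1 `COc1cc(-c2nnc3n2NC(c2ccco2)C(C(=O)c2ccccc2C)S3)cc(OC)c1OC` carries a 2-methylphenyl on the carbonyl carbon, and in a functional assay on PC-3 cells (Homo sapiens) for cytotoxicity, read by MTT assay, with a stated time of 48 h (on this read-out higher numbers stand for weaker inhibition and lower numbers for stronger inhibition), compound 1 gives 88400 nM. Compound 2 `COc1cc(-c2nnc3n2NC(c2ccco2)C(C(=O)c2ccc(C(F)(F)F)cc2)S3)cc(OC)c1OC` carries a 4-(trifluoromethyl)phenyl in the same place, and in this assay compound 2 gives 77500 nM. Among the compounds with values here, the only step known, a 1.1-fold lower number from compound 1 to compound 2 (0.06 log units; within the scatter), is within the scatter, so the two numbers cannot be told apart and compound 2 stands level with compound 1.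

Compound 3 `COc1cc(-c2nnc3n2NC(c2ccco2)C(C(=O)c2cccc(Br)c2)S3)cc(OC)c1OC` continues the same kind of exchange: 3-bromophenyl in place of 4-(trifluoromethyl)phenyl on a carbonyl carbon. Within the data shown here, the one measured step that bears on it, a 1.1-fold lower number from compound 1 to compound 2 (0.06 log units; within the scatter), shows that swapping one substituted phenyl for another on this carbonyl carbon left the read-out unchanged. On that basis the expected change in this assay from compound 2 to compound 3 is none beyond the scatter, that is a 1.0-fold higher number from compound 2 to compound 3 (0.01 log units; within the scatter). For compound 3 the estimate in this assay is therefore 80000 nM, with a range from 35000 nM to 200000 nM.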

Compound 3, half-maximal inhibitory concentration: 63900 nM
For compound 3 the middle estimate is 1.3-fold (0.10 log units) above the measured one; the measured number falls inside the stated range.
By their numbers in this assay, from the lowest: compounds 3, 2 and 1 (each within the scatter of the next).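

With a third group in place, the flatness seen so far extends beyond a single pair: in this assay the exchange of 4-(trifluoromethyl)phenyl for 3-bromophenyl gives a 1.2-fold lower number from compound 2 to compound 3 (0.08 log units; within the scatter), and the comparison with the 2-methylphenyl ketone gives a 1.4-fold lower number from compound 1 to compound 3 (0.14 log units; within the scatter). Neither step leaves the scatter, so 2-methylphenyl, 4-(trifluoromethyl)phenyl and 3-bromophenyl on this carbonyl carbon cannot be told apart, even though the group entering here has 7 heavy atoms and brings bromine, against 10 heavy atoms and three fluorines in the group leaving. Nothing measured here accounts for why these three groups read alike.

From the compounds shown here alone, the three compounds all keep a substituted phenyl on the carbonyl carbon, so it remains open whether a phenyl carrying an amine or a carboxylic acid, or a saturated group such as cyclohexyl or a longer alkyl chain in its place, would move the number beyond the scatter. The rest of the shared core is the same throughout, which leaves open whether a change elsewhere on it would shift the read-out more than any exchange at this carbonyl carbon has.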